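A few compounds are considered here, and "the series" means these few. Any claim that something is new, unique, unknown or untested is made for them only; others in the source may bear on it.

Within the data shown here, in a functional assay on BaF3 cells (Mus musculus) for inhibition, read by CCK-8 assay, with a stated time of 72 h (on this read-out higher numbers stand for weaker inhibition of growth and lower numbers for stronger inhibition of growth), compound 1 `Cc1ccc(NC(=O)Nc2ccc(Oc3cc(NCc4ccccc4)ncn3)cc2)cc1C(F)(F)F` gives 3010 nM and compound 2 `Cc1ccc(NC(=O)Nc2ccc(Oc3cc(N4CCNC[C@@H]4C)ncn3)cc2)cc1C(F)(F)F` gives 8120 nM as the higher of the two numbers so far. Compound 3 `Cc1ccc(NC(=O)Nc2ccc(Oc3cc(NCCN)ncn3)cc2)cc1C(F)(F)F` has (2-aminoethyl)amino in place of 2-methylpiperazin-1-yl on an aromatic carbon on the same core. Among the measured compounds shown here, only one measured step touches that carbon, a 2.7-fold higher number from compound 1 to compound 2 (0.43 log units; beyond the scatter), modest and beyond the scatter, and it involved a different pair of groups. So no step beyond the scatter is expected in this assay for this change. Compound 3 is estimated at 6000 nM with an expected range from 2000 nM to 16000 nM in this read-out. The expected step is a 1.4-fold lower number from compound 2 to compound 3 (0.13 log units; within the scatter) on this estimate.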

Compound 3, concentration for 50% growth inhibition: > 10000 nM
Compound 3 gave a limit, no number; the forecaster's own chance of this, stated with the estimate: 10%; middle value at least 1.6-fold (0.22 log units) from the limit.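

In this assay compound 3 gives > 10000 nM, which is a limit of the assay and not a number. The step to the open-chain (2-aminoethyl)amino is an at least 1.2-fold higher number from compound 2 to compound 3 (0.09 log units; that floor lies within the scatter), so this carbon's two amine groups without a phenyl cannot yet be ranked. The comparison with benzylamino is firmer, an at least 3.3-fold higher number from compound 1 to compound 3 (0.52 log units; beyond the scatter), and leaves compound 1 with the strongest inhibition of growth among the three compounds.

As far as these compounds go, the true size of the step from compound 2 remains open. So does whether a phenethylamino or morpholin-4-yl group on this carbon would match or improve on benzylamino.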